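Widening the Saturated Ring on the Core of Compound 1

A few compounds are considered here, and "the series" means these few. Any claim that something is new, unique, unknown or untested is made for them only; others in the source may bear on it.

Compound 1 `CC(=O)N[C@@H]1CCC[C@H](C(=O)Nc2cc(-c3cnn4c3CCCC4)c(Cl)cn2)C1`: 3.2
Compound 2 `CC(=O)N[C@@H]1CCC[C@H](C(=O)Nc2cc(-c3cnn4ccccc34)c(Cl)cn2)C1`: 3.6
Compound 3 `CC(=O)N[C@@H]1CCC[C@H](C(=O)Nc2cc(-c3cnn4c3CCC4)c(Cl)cn2)C1`: 2.9

All three compounds were measured in a physicochemical assay for lipophilicity, using the shake flask method, measured as octanol-water partition, at pH 7.4; a lower number here means a more polar compound, a higher number a more lipophilic compound. Among them compound 1 stands second highest; it lies nearest to compound 3, which gives 2.9, and furthest from compound 2, which gives 3.6.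

Compound 4 `CC(=O)N[C@@H]1CCC[C@H](C(=O)Nc2cc(-c3cnn4c3CCCCC4)c(Cl)cn2)C1` is the next step from compound 1. The change is a group of 10 heavy atoms (8 carbon, 2 nitrogen; one five-membered aromatic ring with 2 hetero atoms, one seven-membered non-aromatic ring with 1 hetero atom) in place of a group of 9 heavy atoms (7 carbon, 2 nitrogen; one five-membered aromatic ring with 2 hetero atoms, one six-membered non-aromatic ring with 1 hetero atom), on an aromatic carbon.

Within the data shown here, the step that bears most directly on this is the one from compound 1 to compound 3, where the non-aromatic ring lost one carbon: a number 0.30 log units lower from compound 1 to compound 3 (within the scatter). The step from compound 2 to compound 3 points the same way, a number 0.70 log units lower from compound 2 to compound 3 (beyond the scatter), though it also exchanges an aromatic ring for a non-aromatic one. Adding one carbon to the non-aromatic ring of compound 1 is therefore expected to move this assay modestly upward, by about a number 0.30 log units higher from compound 1 to compound 4 (within the scatter). Compound 4 is estimated at 3.5, with a range from 3.1 to 3.9.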

Compound 4, distribution coefficient: 3.6
For compound 4 the middle estimate is 0.10 log units below the measured one; low and high end bracket the measured number.
By their numbers in this assay, from the lowest: compounds 3 and 1 (each within the scatter of the next); then compounds 2 and 4 (each within the scatter of the next).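

Adding one carbon to the non-aromatic ring of compound 1 gives a number 0.40 log units higher from compound 1 to compound 4 (beyond the scatter) in this assay, a step that clears the scatter, whereas removing one carbon did not. The two ends of this set of non-aromatic rings stand clearly apart, with a number 0.70 log units higher from compound 3 to compound 4 (beyond the scatter) as the full span from the five-membered to the seven-membered ring. The seven-membered non-aromatic ring also reaches the level of the six-membered aromatic ring, with no change at the digits printed from compound 2 to compound 4 (within the scatter) in this comparison.

Still open, as far as these compounds go, is whether an eight-membered non-aromatic ring would continue this rise, and how an oxygen atom in the seven-membered ring, or an amine or hydroxyl group on it, would change the number. No measurement shown here accounts for the size of these steps.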